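Adding Chlorine to Two Norepinephrine Transporter Cores

The source may report more compounds than this note shows. Statements on the series, on what has been measured and on what is new or still open speak of the compounds shown alone.

Compound 1 `NC1=NCC(CC2=Cc3ccccc3CC2)O1` and compound 3 `C1=NCC(CC2CCc3ccccc3C2)N1` are built on different cores; how the two cores differ is not broken down here. In a functional assay for binding affinity to Norepinephrine transporter (Rattus norvegicus), read by radioligand binding, in the presence of a further agent that is not named here (on this read-out higher numbers stand for weaker inhibition and lower numbers for stronger inhibition), compound 1 gives 1000 nM. In this assay compound 3 gives 100 nM, a lower number than compound 1, and that gap lies beyond the usual scatter of such measurements. Compound 2 `NC1=NCC(CC2=Cc3c(Cl)cccc3CC2)O1` carries the change (chloro in place of hydrogen on an aromatic carbon). For compound 2 the value in this assay is a limit, < 1000 nM, and not a number. The step of a number no higher from compound 1 to compound 2 (the limit leaves the size open) therefore has no readable size, which rests on (the limit of < 1000 nM in this assay, at which 1 of the 3 values shown sits). Compound 4 `Clc1cccc2c1CC(CC1CN=CN1)CC2` carries the same change, (chloro in place of hydrogen on an aromatic carbon), on the core of compound 3, and has not yet been measured in this assay. Since the size of that earlier step is open, the expectation for compound 4 rests on compound 3 with its 100 nM and on the direction of a number no higher from compound 1 to compound 2 (the limit leaves the size open), so the number is expected not to rise. Compound 4 is estimated at 60 nM, between 20 nM and 200 nM, which means an expected step of a 1.7-fold lower number from compound 3 to compound 4 (0.22 log units; within the scatter).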

Compound 4, inhibition constant: 100 nM
Beside the measured number, compound 4's estimate is 1.7-fold (0.22 log units) below it, within the range that was stated.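

On the second core, chloro in place of hydrogen on an aromatic carbon shows no change at the digits printed from compound 3 to compound 4 (within the scatter) in this assay, so on this core the added chlorine brings no shift that stands out from ordinary repeat measurements. Set beside the earlier step, this result does not show that the change behaves alike on the two cores, nor that it behaves differently: the same change on two cores in this assay, a number no higher (the limit leaves the size open) from compound 1 to compound 2 and no change at the digits printed (within the scatter) from compound 3 to compound 4; the limit leaves it open whether they differ. On these data alone, the earlier step cannot be read for size, and the comparison stays open because the value of compound 2 is a limit and not a number: the limit of < 1000 nM in this assay, at which 1 of the 4 values shown sits.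

The compounds shown carry only chloro as the added group, so they leave open how a fluoro, a methyl or a methoxy group would read in the same place on either core. They also leave open what chloro would do on a different aromatic carbon of the ring, so this single swap gives no general rule for the series.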